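A few compounds are considered here, and "the series" means these few. Any claim that something is new, unique, unknown or untested is made for them only; others in the source may bear on it.

In a functional assay on HeLa cells (Homo sapiens) for cytotoxicity, read by MTT assay, with a stated time of 48 h, in the absence of a further agent (on this read-out higher numbers stand for weaker inhibition and lower numbers for stronger inhibition), compound 1 `O=C(NCc1ccccc1)c1csc(-c2c[nH]c3ccccc23)n1` gives 9510 nM. Compound 2 `O=C(Nc1ccccc1)c1csc(-c2c[nH]c3ccccc23)n1` stands at the limit of this assay, > 100000 nM, a limit and not a number; it is the limit described by the limit of > 100000 nM in this assay, at which 1 of the 2 values shown sits. Between these two compounds a single structural change was measured: a phenyl in place of a benzyl on the amide nitrogen gave an at least 10-fold higher number from compound 1 to compound 2 (1.02 log units; beyond the scatter), a large loss of inhibition.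

Compound 3 `Cc1ccc(NC(=O)c2csc(-c3c[nH]c4ccccc34)n2)cc1` differs from compound 2 by methyl in place of hydrogen on an aromatic carbon. Among the compounds with values here, no measured step concerns a methyl in place of hydrogen on the aromatic ring, so the only measured step, an at least 10-fold higher number from compound 1 to compound 2 (1.02 log units; beyond the scatter), bears on compound 3 merely by fixing the starting point, a compound already at the limit of this assay. With nothing pointing in either direction, the expected step is a number no higher from compound 2 to compound 3 (the limit leaves the size open), that is, no step beyond the scatter, and the chance that this assay again reports only a limit remains high. The estimate for compound 3 in this assay is therefore 100000 nM, with a range from 30000 nM to 300000 nM.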

Compound 3, half-maximal inhibitory concentration: > 100000 nM
Compound 3 was reported as a limit; the forecaster's own chance of this, stated with the estimate: 65%; the middle value lies on the limit itself.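

In this assay, the 4-methylphenyl group on the amide nitrogen does not restore what the benzyl group of compound 1 gives: putting it in place of benzyl produces an at least 10-fold higher number from compound 1 to compound 3 (1.02 log units; beyond the scatter). Compound 3 is reported as > 100000 nM, which is a limit and not a number. The step from compound 2 to compound 3 cannot be read, so any effect of the methyl on this ring stays hidden, and compound 3 simply joins compound 2 at the same limit: the limit of > 100000 nM in this assay, at which 2 of the 3 values shown sit.

Compound 1 alone carries a readable number among the compounds shown, so it remains open whether a methoxy group, a chlorine or an amine on the phenyl ring of compound 2 would bring the value back into the range where a number can be read. On these data alone, it is also open how a methyl or a methoxy group on the ring of the benzyl group, or a longer chain such as phenylethyl in its place, would move the value of compound 1.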